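The source may report more compounds than this note shows. Statements on the series, on what has been measured and on what is new or still open speak of the compounds shown alone.

Measured so far:
Compound 1 `CCOc1ccc(NC(=O)c2ccc(C(CC)(CC)c3ccc(OCCC(O)(CC)CC)c(C)c3)n2CC)cc1`: in a functional assay on PC-3 cells (Homo sapiens) for antiproliferative activity, read by MTT assay, with a stated time of 48 h (a lower number here means a stronger inhibitor, a higher number a weaker inhibitor), compound 1 gives > 50000 nM, which is a limit of the assay rather than a number.
Compound 2 `CCn1c(C(=O)NC(C)C(=O)O)ccc1C(CC)(CC)c1ccc(OCCC(O)(CC)CC)c(C)c1`: in this assay compound 2 gives 11700 nM.

Compound 1 thus sits at the limit (the limit of > 50000 nM in this assay, at which 1 of the 2 values shown sits), with no measurable number of its own. The compound still to be measured is compound 3 `CCn1c(C(=O)NC(C)CO)ccc1C(CC)(CC)c1ccc(OCCC(O)(CC)CC)c(C)c1`. It differs from compound 1 by 1-(hydroxymethyl)ethyl in place of 4-ethoxyphenyl on an amide-type nitrogen. Within the data shown here, the one measured step that bears on this change is an at least 4.2-fold lower number from compound 1 to compound 2 (0.63 log units; beyond the scatter), where 1-carboxyethyl, another short chain, took the place of 4-ethoxyphenyl on the amide-type nitrogen. A step in the same direction is expected here, estimated as an at least 2.7-fold lower number from compound 1 to compound 3 (0.44 log units; beyond the scatter), while a real chance remains that compound 3 again reaches only the limit. Compound 3 is therefore expected to give about 18000 nM, within a range from 6000 nM to 50000 nM.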

Compound 3, half-maximal inhibitory concentration: 7870 nM
Compound 3: the middle estimate sits 2.3-fold (0.36 log units) above what was measured; the measured number falls inside the stated range.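

In this assay, a second short chain in place of 4-ethoxyphenyl on the amide-type nitrogen gives an at least 6.3-fold lower number from compound 1 to compound 3 (0.80 log units; beyond the scatter), so the drop seen with 1-carboxyethyl does not depend on the carboxy group. Hydroxymethyl in place of carboxy on that chain gives a 1.5-fold lower number from compound 2 to compound 3 (0.17 log units; within the scatter), so these two chains cannot be told apart here. The true size of the step from compound 1 stays unknown because compound 1 gives a limit, not a number: the limit of > 50000 nM in this assay, at which 1 of the 3 values shown sits.

Both chains shown carry oxygen, so it remains open whether a plain isopropyl group would do as well, or whether an amine on the chain would do better or worse. Going by these compounds, it is also open whether losing the ring is what counts, which a benzyl group on the same nitrogen could help to settle.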